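The source may report more compounds than this note shows. Statements on the series, on what has been measured and on what is new or still open speak of the compounds shown alone.

Series of amides sharing one core. Compound 1 `Cc1ccc(OCC(=O)N(Cc2cccs2)C2CCCCC2)cc1` gives 40000 nM in an assay on HEK293 cells for agonist activity at transient receptor potential cation channel subfamily M member 8 (Homo sapiens), read by fluorescence and calcium flux, with a stated time of 15 min; on this read-out lower numbers stand for an effect already at smaller amounts and higher numbers for an effect only at larger amounts of compound; compound 2 `Cc1ccc(OCC(=O)N(C)Cc2cccs2)cc1` gives 400 nM; compound 3 `Cc1ccc(OCC(=O)N(Cc2cccs2)c2ccncc2)cc1` gives 52 nM. Compound 3 stands lowest of the three: a 7.7-fold lower number from compound 2 to compound 3 (0.89 log units; beyond the scatter), a 770-fold lower number from compound 1 to compound 3 (2.89 log units; beyond the scatter). Compound 4 `Cc1ccc(OCC(=O)N(Cc2cccs2)c2cn[nH]c2)cc1` differs from compound 3 by 1H-pyrazol-4-yl in place of pyridin-4-yl on an amide-type nitrogen. For the measured compounds named here, both measured steps into compound 3 replace a methyl or cyclohexyl with pyridin-4-yl and are large or modest; no measured step exchanges one aromatic ring for another, so they bear on compound 4 only loosely. A step near the scatter or slightly upward is expected for compound 4, a 1.9-fold higher number from compound 3 to compound 4 (0.28 log units; within the scatter). Compound 4 is estimated at 100 nM, range 30 nM to 400 nM.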

Compound 4, half-maximal effective concentration: 1.4 nM
The estimate for compound 4 lay 71-fold (1.85 log units) above the measured number; measured number outside the range, below it.
By their numbers in this assay, from the lowest: compound 4; then compound 3; then compound 2; then compound 1.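

In this assay, one aromatic ring in place of another on the amide-type nitrogen is far from neutral (see a 37-fold lower number from compound 3 to compound 4 (1.57 log units; beyond the scatter)), so this position separates aromatic rings from each other as well as from saturated groups. The 1H-pyrazol-4-yl group also widens the range seen at this position, with a 290-fold lower number from compound 2 to compound 4 (2.46 log units; beyond the scatter) and a 29000-fold lower number from compound 1 to compound 4 (4.46 log units; beyond the scatter). Nothing on hand explains the gain over pyridin-4-yl.

As far as these compounds go, it remains open whether the hydrogen-bond donor matters, which a methyl in place of the hydrogen on the pyrazole ring nitrogen would test. From the compounds shown here alone, whether the ring size matters also remains open.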